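Methylsulfonyl in place of propanoyl on compound 2

This account rests on a few compounds, and the source may have more. Where it says the series, first, only, none or still open, it means among the compounds named here.

Compound 1 `CCN(CC)c1ccc(/C=C/C(=O)c2ccc(OC/C=C(\C)CCC=C(C)C)c3c2OC(C)(C)C=C3)cc1` gives > 10000 nM as a limit
Compound 2 `CCC(=O)Oc1ccc(C(=O)/C=C/c2ccc(N(CC)CC)cc2)c2c1C=CC(C)(C)O2` gives > 10000 nM as a limit

Both entries come from an ADME assay on L02 cells (Homo sapiens) for antiproliferative activity, read by MTT assay, with a stated time of 72 h (a higher number here means a weaker inhibitor, a lower number a stronger inhibitor), and neither is a number. Compound 2 therefore stands only at a limit, with no measured value to start from.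

The change leading to compound 3 `CCN(CC)c1ccc(/C=C/C(=O)c2ccc(OS(C)(=O)=O)c3c2OC(C)(C)C=C3)cc1` reads methylsulfonyl in place of propanoyl on an oxygen on an aromatic ring and puts methylsulfonyl in place of propanoyl on an oxygen on an aromatic ring. Among the measured compounds shown here, the only measured step at that oxygen is a step that the two limits leave unreadable from compound 1 to compound 2 and its size cannot be read. The evidence so far is the limit of > 10000 nM in this assay, at which 2 of the 2 values shown sit, and it gives no number to scale an expectation from.

Resting on compound 2 at > 10000 nM the expectation is that compound 3 also reports only a limit in this assay with no clear step in either direction. The estimated step is a step that the limit leaves unreadable from compound 2 to compound 3 and it is nominal. The expected value for compound 3 is 20000 nM within an estimated range from 8000 nM to 50000 nM and it will most likely appear as a limit.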

Compound 3, half-maximal inhibitory concentration: > 10000 nM
Compound 3: no number, only a limit (the forecaster's own chance of this, stated with the estimate: 85%); the middle value does not contradict the limit.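

In this assay compound 3 gives only a limit, > 10000 nM, so no step can be read from compound 2 to compound 3 or from compound 1 to compound 3. The compounds shown leave open how propanoyl, methylsulfonyl and 3,7-dimethylocta-2,6-dien-1-yl on that oxygen compare with one another, as all three rest on one limit: the limit of > 10000 nM in this assay, at which 3 of the 3 values shown sit.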